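This account rests on a few compounds, and the source may have more. Where it says the series, first, only, none or still open, it means among the compounds named here.

Measured so far:
compound 1, `Brc1ccc(OC[C@@H]2CCN2)cn1`: 0.021 nM
compound 2, `c1ccc(-c2ccc(OC[C@@H]3CCN3)cn2)cc1`: 2.3 nM
compound 3, `Clc1ncc(OC[C@@H]2CCN2)cc1Br`: 0.015 nM

All three values come from an assay on brain for binding affinity to Neuronal acetylcholine receptor; alpha4/beta2 (Rattus norvegicus), read by radioligand binding (on this read-out lower numbers stand for stronger inhibition and higher numbers for weaker inhibition), where compound 1 and compound 3 lie close together. The change from compound 1 to compound 2, (phenyl in place of bromo on an aromatic carbon), gave a 110-fold higher number from compound 1 to compound 2 (2.04 log units; beyond the scatter). Compound 4, `Clc1ncc(OC[C@@H]2CCN2)cc1-c1ccccc1`, is not yet measured; it arises from compound 3 by the same kind of change, (phenyl in place of bromo on an aromatic carbon). The surroundings differ: in compound 1 the bromo sits next to the ring nitrogen and para to a group of 6 heavy atoms, whereas in compound 3 it sits ortho to a chloro group, two atoms from the ring nitrogen and meta to a group of 6 heavy atoms. How the two cores themselves differ is not broken down here. A large step in this assay is expected, an 80-fold higher number from compound 3 to compound 4 (1.90 log units; beyond the scatter), because a 110-fold higher number from compound 1 to compound 2 (2.04 log units; beyond the scatter) was large, though the different surroundings leave room for a smaller one. Compound 4 is expected to give about 1.2 nM, between 0.2 nM and 8 nM.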

Compound 4, inhibition constant: 0.022 nM
Estimate against measurement, compound 4: 55-fold (1.74 log units) above, and the stated range ends above it.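

Placing phenyl where bromo stood barely moved the number on the core of compound 3, with a 1.5-fold higher number from compound 3 to compound 4 (0.17 log units; within the scatter). The change therefore does not carry over from one core to the other with the same size: the same change on two cores in this assay, a 110-fold higher number (2.04 log units; beyond the scatter) from compound 1 to compound 2 and a 1.5-fold higher number (0.17 log units; within the scatter) from compound 3 to compound 4, 75-fold (1.87 log units) apart, beyond the scatter of two such steps. This shows that a large step on one core in this series does not predict a large step on another, but two pairs cannot show which difference between the cores is responsible or how the change would behave on a further core.

The compounds shown leave open whether an amine or a longer chain, ortho to a chloro group, would also give a number close to that of compound 3. They also leave open whether phenyl itself can be replaced by another group at this place without a large step.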